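This account rests on a few compounds, and the source may have more. Where it says the series, first, only, none or still open, it means among the compounds named here.

Compound 1 `c1csc(-c2ccccc2NCC2=NCCN2)c1` carries a thiophen-2-yl group on the shared core, and in a functional assay for activation of Alpha-1B adrenergic receptor (Homo sapiens), read by calcium flux (a lower number here means that less compound is needed, a higher number that more compound is needed for the effect), compound 1 gives 5.75 nM. Compound 2 `Cc1ccsc1-c1ccccc1NCC1=NCCN1` differs from it by one change, (methyl in place of hydrogen on an aromatic carbon), and in this assay compound 2 gives 112 nM; the step is a 19-fold higher number from compound 1 to compound 2 (1.29 log units; beyond the scatter). Compound 3 `c1ccc(-c2ccccc2NCC2=NCCN2)nc1` carries a different core, the difference being (pyridin-2-yl in place of thiophen-2-yl on an aromatic carbon), and in this assay compound 3 gives 30.2 nM, so that a 5.3-fold higher number from compound 1 to compound 3 (0.72 log units; beyond the scatter) and a 3.7-fold lower number from compound 2 to compound 3 (0.57 log units; beyond the scatter).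

Compound 4 `Cc1cccnc1-c1ccccc1NCC1=NCCN1` has not yet been measured. It differs from compound 3 by methyl in place of hydrogen on an aromatic carbon. For the measured compounds named here, this is the same kind of change as the one from compound 1 to compound 2, but the surroundings differ: there the methyl entered on a five-membered aromatic ring with 1 sulfur, next to the ring atom that bears a large group, two ring bonds from the ring sulfur; here it enters on a six-membered aromatic ring with 1 nitrogen, ortho to a large group, two atoms from the ring nitrogen. Because the earlier step of a 19-fold higher number from compound 1 to compound 2 (1.29 log units; beyond the scatter) was large, a step of similar direction and size, a 15-fold higher number from compound 3 to compound 4 (1.17 log units; beyond the scatter), is expected for compound 4 in this assay, though the different ring leaves this uncertain. Compound 4 is therefore estimated at 450 nM, expected to lie between 120 nM and 1500 nM.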

Compound 4, half-maximal effective concentration: < 100000 nM
Compound 4: no number, only a limit; the forecaster's own chance of this, stated with the estimate: 5%; the middle value lies beyond the limit too.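

In this assay compound 4 gives < 100000 nM, which is a limit of the assay and not a number. The step from compound 3 to compound 4 therefore cannot be read. The compounds shown leave open how far methyl in place of hydrogen on this six-membered aromatic ring with 1 nitrogen moves the number, and whether that step resembles a 19-fold higher number from compound 1 to compound 2 (1.29 log units; beyond the scatter).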